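The compounds below may be only part of what the source reports. "The series", "measured", "known", "first", "only" and "open" are said of these compounds alone.

Measured compounds:
- compound 1, `COc1ccc(-c2c(Nc3ccc(C)c(O)c3)c3ccccc3oc2=O)cc1`: 12300 nM
- compound 2, `COc1ccc(-c2c(Nc3ccc(C)cc3)c3ccccc3oc2=O)cc1`: 64800 nM
- compound 3, `COc1ccc(-c2c(Nc3ccc(NC(C)=O)cc3)c3ccccc3oc2=O)cc1`: "not determined" (no result reported)

These compounds share one core and differ only in the group carried on the nitrogen attached to it. Going by the values given here, in a functional assay on HCT-116 cells (Homo sapiens) for antiproliferative activity, read by MTT assay, with a stated time of 48 h (on this read-out higher numbers stand for weaker inhibition and lower numbers for stronger inhibition), compound 1 gives 12300 nM, and compound 2 gives 64800 nM; the one step between them, a 5.3-fold higher number from compound 1 to compound 2 (0.72 log units; beyond the scatter), is the only measured step available. For compound 3 no number was obtained in this assay, so it stands without a value and offers no direct anchor.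

Compound 4, `COc1ccc(-c2c(Nc3cccc(C(F)(F)F)c3)c3ccccc3oc2=O)cc1`, is the next compound to be examined. It differs from compound 3 in one place:

3-(trifluoromethyl)phenyl in place of 4-acetamidophenyl on a nitrogen on an aromatic ring

Among the compounds with values here, no measured step matches this exchange: the step from compound 1 to compound 2 concerns a hydroxy group, not the groups exchanged here, so it bears on the expectation only by showing the spread of values the core can give. With compound 3 unmeasured, the expectation for compound 4 can rest only on the range spanned by compound 1 and compound 2. Compound 4 is therefore expected to give about 30000 nM in this assay, within an estimated range of 8000 nM to 110000 nM.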

Compound 4, half-maximal inhibitory concentration: 55700 nM
For compound 4 the middle estimate is 1.9-fold (0.27 log units) below the measured one; measured number inside the range.
By their numbers in this assay, from the lowest: compound 1; then compounds 4 and 2 (each within the scatter of the next).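

In this assay, swapping the 4-methylphenyl on the nitrogen for 3-(trifluoromethyl)phenyl leaves the result within the usual scatter (a 1.2-fold lower number from compound 2 to compound 4 (0.07 log units; within the scatter)). Going by these compounds alone, replacing 3-hydroxy-4-methylphenyl with the same group gives a higher number, meaning weaker inhibition (a 4.5-fold higher number from compound 1 to compound 4 (0.66 log units; beyond the scatter)), so among the three measured groups, only the one carrying a hydroxy stands apart, much as it does when the hydroxy alone is removed (a 5.3-fold higher number from compound 1 to compound 2 (0.72 log units; beyond the scatter)). The step from compound 3 cannot be read, and no measurement shown gives a cause for the other steps.

The compounds shown leave open whether a hydroxy added to the 3-(trifluoromethyl)phenyl ring would lower the number as well. They also leave open how an amine or a carboxylic acid on that ring would compare with compound 1.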